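The source may report more compounds than this note shows. Statements on the series, on what has been measured and on what is new or still open speak of the compounds shown alone.

Measured compounds, cytotoxicity against Ehrlich cells:
- compound 1, `COc1cc(N2C(N)=C(C#N)C(/C=C/c3ccccc3)C3=C2CC(C)(C)CC3=O)cc(OC)c1OC`: in a functional assay on Ehrlich cells (Mus musculus) for cytotoxicity, tested at 50 ug/mL (a lower number here means a weaker effect, a higher number a stronger effect of the compound at the concentration tested), compound 1 gives 30%
- compound 2, `COc1cc(N2C(N)=C(C#N)C(c3c(OC)ccc4ccccc34)C3=C2CC(C)(C)CC3=O)cc(OC)c1OC`: compound 2 gives 10%
- compound 3, `COc1cc(N2C(N)=C(C#N)C(c3ccc(Cl)cc3Cl)C3=C2CC(C)(C)CC3=O)cc(OC)c1OC`: compound 3 gives 95%

Compound 2 stands lowest of the three numbers in this assay. Compound 1 is nearest to it and compound 3 furthest, both gaps beyond the scatter. The unmeasured compound 4, `COc1cc(N2C(N)=C(C#N)C(c3ccc(C)cc3)C3=C2CC(C)(C)CC3=O)cc(OC)c1OC`, differs from compound 2 in one place: 4-methylphenyl in place of 2-methoxynaphthalen-1-yl on a saturated ring carbon. The three compounds and compound 4 share the same core and differ only in the group on that saturated ring carbon, so both measured steps bear on the change. a number 20 percentage points lower from compound 1 to compound 2 (beyond the scatter); read from compound 2, that step runs upward. a number 85 percentage points higher from compound 2 to compound 3 (beyond the scatter). Every departure from compound 2 seen so far has gone up in this assay, once modestly and once by a large amount. Within the data shown here, compound 4 carries a single aromatic ring, as compound 3 does, but with a methyl rather than two chlorines, and no measured compound tells how much of the large step in compound 3 depends on the chlorines. Among the measured compounds shown here, an upward step of moderate size is therefore expected, smaller than the one to compound 3; the expected step is a number 30 percentage points higher from compound 2 to compound 4 (beyond the scatter). Compound 4 is estimated at 40%, with a range from 15% to 75%.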

Compound 4, a percentage reported as activity, at one concentration (the size of the read-out at that concentration, not a potency): 60%
The estimate for compound 4 lay 20 percentage points below the measured number; the range from low to high includes it.
By their numbers in this assay, from the lowest: compound 2; then compound 1; then compound 4; then compound 3.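

In this assay, 4-methylphenyl on this saturated ring carbon in place of 2-methoxynaphthalen-1-yl gives a number 50 percentage points higher from compound 2 to compound 4 (beyond the scatter), which shows that a large rise from compound 2 does not need the chlorines of compound 3. Those chlorines still count for something within the single-ring pair, since 4-methylphenyl in place of 2,4-dichlorophenyl gives a number 35 percentage points lower from compound 3 to compound 4 (beyond the scatter), although this change alters the substituents on the ring in more than one way and cannot be split into the share of each. Against 2-phenylethenyl, the same group gives a number 30 percentage points higher from compound 1 to compound 4 (beyond the scatter), so the count of aromatic rings alone does not order the series: compound 1 also carries one aromatic ring, yet it stays well under compound 4 and compound 3.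

No measurement at hand accounts for these differences. Still open, going by these compounds, is whether an unsubstituted phenyl or a 4-chlorophenyl would fall closer to compound 4 or to compound 3, and whether a ring carrying an amine or a carboxylic acid at this carbon would keep the read-out.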